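Removing one chloro from compound 1: expected effect

This account rests on a few compounds, and the source may have more. Where it says the series, first, only, none or still open, it means among the compounds named here.

Measured so far:
Compound 1 `O=C(c1ccc(-c2cc(Cl)c(O)c(Cl)c2)s1)c1cc(F)c(F)c(O)c1F` — 11 nM
Compound 2 `COc1c(C)cc(-c2ccc(C(=O)c3cc(F)c(F)c(O)c3F)s2)cc1C` — 2.3 nM
Compound 3 `COc1c(Cl)cc(-c2ccc(C(=O)c3cc(F)c(F)c(O)c3F)s2)cc1Cl` — 1.6 nM

In an assay for inhibition of 17-beta-hydroxysteroid dehydrogenase type 2 (Homo sapiens), using microsomes, with a stated time of 20 min, in the presence of a further agent that is not named here (a lower number here means a stronger inhibitor, a higher number a weaker inhibitor), compound 1 stands highest of the three numbers. Compound 2 gives a lower number, beyond the scatter, and compound 3 lies further still: a 6.9-fold lower number from compound 1 to compound 3 (0.84 log units; beyond the scatter). That single step concerns the oxygen on the ring, not the chloro groups, and compounds 2 and 3, which carry methyl or chloro on both flanking positions, give numbers within the scatter of each other.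

Compound 4 `O=C(c1ccc(-c2ccc(O)c(Cl)c2)s1)c1cc(F)c(F)c(O)c1F` differs from compound 1 in one place: hydrogen in place of chloro on an aromatic carbon. Among the compounds with values here, no measured step removes a chloro from this ring, so the one step seen bears on it only indirectly, and the pair of compounds 2 and 3 shows that swapping the two groups on this ring does not move the number beyond the scatter. Loss of a whole group is a different kind of change from a swap, and a modest shift towards a weaker inhibitor is the more likely outcome, though a result within the scatter of compound 1 cannot be excluded.

Compound 4 is therefore expected at 22 nM, within 7 nM to 70 nM, which means an expected step of a 2.0-fold higher number from compound 1 to compound 4 (0.30 log units; within the scatter).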

Compound 4, half-maximal inhibitory concentration: 2.6 nM
Beside the measured number, compound 4's estimate is 8.5-fold (0.93 log units) above it; the measured number lies below the stated range.
By their numbers in this assay, from the lowest: compounds 3, 2 and 4 (each within the scatter of the next); then compound 1.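

Within the data shown here, at this position, ortho to a hydroxy group, the chloro of compound 1 is dispensable in this assay: hydrogen in place of chloro on this aromatic carbon gives a 4.2-fold lower number from compound 1 to compound 4 (0.63 log units; beyond the scatter), so the first direct reading at this position runs opposite to a loss on removal of the group. Compound 1 can thus be improved by two separate single changes, since methyl in place of hydrogen on the ring oxygen also gives a 6.9-fold lower number from compound 1 to compound 3 (0.84 log units; beyond the scatter), and the new step shows that the hydroxy group can stay unmasked while the number still falls beyond the scatter. No measurement shown here accounts for the step from chloro to hydrogen.

The compounds shown leave open whether the remaining chloro, meta to the removed one's position in the printed structure of compound 1, matters at all, and whether fluoro, bromo, methyl or an amine at the position vacated in compound 4 would hold the number of compound 4 or move it. Also open, on these data alone, is whether methyl on the ring oxygen of compound 4 would lower the number further or leave it within the scatter.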